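Methoxyphenyl rearranged on the anilino nitrogen of the shared core

The source may hold more compounds than are shown below. What is called first, only, known or untested is meant among the compounds shown, and "the series" means these compounds.

Compound 2 `CNC(=O)c1ccccc1Oc1nc(Nc2ccccc2OC)ncc1Br` stands at the assay limit in a functional assay on MDA-MB-468 cells (Homo sapiens) for antiproliferative activity, read by MTT assay, with a stated time of 24 h (on this read-out lower numbers stand for stronger inhibition and higher numbers for weaker inhibition), where compound 2 gives > 50000 nM. Compound 1 `CNC(=O)c1ccccc1Oc1nc(Nc2ccc(C(F)(F)F)cc2)ncc1Br` likewise gives only the limit > 50000 nM in this assay. Among the compounds with values here, compound 3 `CNC(=O)c1ccccc1Oc1nc(Nc2cccc(C)c2)ncc1Br` gives 18600 nM in this assay, the one numerical value among the three. Within the data shown here, the single measured step that bears here is an at least 2.6-fold lower number from compound 2 to compound 3 (0.42 log units; beyond the scatter). Compound 4 `CNC(=O)c1ccccc1Oc1nc(Nc2cccc(OC)c2)ncc1Br` differs from compound 2 by 3-methoxyphenyl in place of 2-methoxyphenyl on a nitrogen on an aromatic ring. Because the limit of > 50000 nM in this assay, at which 2 of the 3 values shown sit, marks where compound 2 sits, and the 3-methylphenyl analogue lowered the number to a modest degree, a similar modest lowering in this assay is expected for the 3-methoxyphenyl group. Compound 4 is therefore estimated at 28000 nM, between 10000 nM and 50000 nM. That estimate amounts to an expected at least 1.7-fold lower number from compound 2 to compound 4 (0.25 log units; that floor lies within the scatter).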

Compound 4, half-maximal inhibitory concentration: 17800 nM
Estimate against measurement, compound 4: 1.6-fold (0.20 log units) above; measured number inside the range.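

Moving the methoxy group from 2-methoxyphenyl to 3-methoxyphenyl, with the atoms unchanged and only joined differently, gives an at least 2.8-fold lower number from compound 2 to compound 4 (0.44 log units; beyond the scatter) in this assay, so a rearrangement alone shifts the read-out. Methoxy in place of methyl on an aromatic carbon gives a 1.0-fold lower number from compound 3 to compound 4 (0.02 log units; within the scatter), so this assay does not separate the 3-methylphenyl and 3-methoxyphenyl groups. The first step stays a floor because compound 2 rests on a limit: the limit of > 50000 nM in this assay, at which 2 of the 4 values shown sit.

Going by these compounds, what a carboxylic acid or an amine on this phenyl ring, or a longer chain in place of methoxy, would do remains open.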